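The source may hold more compounds than are shown below. What is called first, only, known or untested is meant among the compounds shown, and "the series" means these compounds.

In a functional assay on PLC-PRF-5 cells (Homo sapiens) for inhibition, read by MTT assay, with a stated time of 72 h (a lower number here means a stronger inhibitor, a higher number a weaker inhibitor), compound 3 `Nc1nc2cc(-c3nn(CCCCCC(=O)NO)c4ncnc(N)c34)ccc2o1` gives > 50000 nM, which is a limit of the assay and not a number. Its true position is therefore unknown. Compound 4 `Nc1nc2cc(-c3nn(CCCCCCC(=O)NO)c4ncnc(N)c34)ccc2o1` differs from it in one place: (hydroxycarbamoyl)methyl in place of hydroxycarbamoyl on a saturated chain carbon, five bonds along the chain from an aromatic nitrogen. On a saturated chain carbon, five bonds along the chain from an aromatic nitrogen, (hydroxycarbamoyl)methyl stands in place of hydroxycarbamoyl.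

Among the measured compounds shown here, no measured pair shows this same change. The nearest guide comes from two other compounds. Compound 1 `CNC(=O)CCCCCCCn1nc(-c2cnc3[nH]ccc3c2)c2c(N)ncnc21` gives 35900 nM. Compound 2 `Nc1ncnc2c1c(-c1cnc3[nH]ccc3c1)nn2CCCCCCC(=O)NO` gives > 50000 nM, again a limit. The step between them, an at least 1.3-fold higher number from compound 1 to compound 2 (0.14 log units; that floor lies within the scatter), alters the end of the chain instead, and it gives only a floor. The wider picture is the limit of > 50000 nM in this assay, at which 2 of the 3 values shown sit.

With so little to go on, no step beyond the scatter is expected, and the estimated step is an at least 1.2-fold lower number from compound 3 to compound 4 (0.09 log units; that floor lies within the scatter). The estimate for compound 4 is 40000 nM, with an expected range from 12000 nM to 70000 nM.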

Compound 4, half-maximal inhibitory concentration: > 50000 nM
Compound 4 gave a limit, no number; the forecaster's own chance of this, stated with the estimate: 55%; middle value at least 1.2-fold (0.09 log units) away from the limit.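

Compound 4 gives > 50000 nM, a limit of the assay and not a number, so its steps from compound 2 and compound 3 cannot be read. The compounds shown leave open whether (hydroxycarbamoyl)methyl in place of hydroxycarbamoyl changes the true potency in this assay, and what stands is only this: the limit of > 50000 nM in this assay, at which 3 of the 4 values shown sit.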